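Swapping bromo for methoxy on two related cores

This account rests on a few compounds, and the source may have more. Where it says the series, first, only, none or still open, it means among the compounds named here.

Four compounds share an unsaturated ketone that links a phenol ring to a sulfur-containing bicyclic ring; they differ in which carbon of that bicycle carries the chain and in one group on the phenol. Compound 1 `O=C(/C=C/c1csc2ccccc12)c1cc(Br)ccc1O` carries a bromo on the phenol and, in a functional assay on A549 cells (Homo sapiens) for antiproliferative activity, read by sulforhodamine B assay, with a stated time of 72 h (a higher number here means a weaker inhibitor, a lower number a stronger inhibitor), compound 1 gives 660 nM. Compound 2 `COc1ccc(O)c(C(=O)/C=C/c2csc3ccccc23)c1` carries a methoxy in its place; in this assay compound 2 gives 580 nM. The change between them is methoxy in place of bromo on an aromatic carbon, and its effect is a 1.1-fold lower number from compound 1 to compound 2 (0.06 log units; within the scatter).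

Compound 3 `O=C(/C=C/c1cc2ccccc2s1)c1cc(Br)ccc1O` has the same atoms as compound 1, joined differently, so that the chain sits on a different carbon of the bicycle; how the two cores differ is not broken down here. In this assay compound 3 gives only a limit, > 10000 nM, and no number. This is the limit of > 10000 nM in this assay, at which 1 of the 3 values shown sits, at which one of the three values sits.

Compound 4 `COc1ccc(O)c(C(=O)/C=C/c2cc3ccccc3s2)c1` is the not yet measured partner of compound 3; the change from compound 3 to compound 4 is methoxy in place of bromo on an aromatic carbon, the same change as from compound 1 to compound 2, made around the same place. Since that change moved the number only within the scatter on the first core, compound 4 is expected to stay near the limit, with a step that the limit leaves unreadable from compound 3 to compound 4. Compound 4 is estimated at 15000 nM, between 5000 nM and 50000 nM, and most likely reported again only as a limit.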

Compound 4, half-maximal inhibitory concentration: > 10000 nM
Compound 4 ended at the assay's limit; the forecaster's own chance of this, stated with the estimate: 75%; the middle value lies beyond the limit too.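

In this assay compound 4 gives > 10000 nM as a limit and not a number. Compound 3 also gives only a limit, so the step from compound 3 to compound 4 cannot be read. The compounds shown leave open how far each of these two compounds lies past the limit, and whether methoxy in place of bromo changes anything on this core.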